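A few compounds are considered here, and "the series" means these few. Any claim that something is new, unique, unknown or untested is made for them only; others in the source may bear on it.

Measured in a functional assay on Calu-3 cells (Homo sapiens) for cytotoxicity, read by WST assay, with a stated time of 72 h; a lower number here means a stronger inhibitor, a higher number a weaker inhibitor:

compound 1, `COc1ccc(-c2cc(-c3cc4ccccc4n3C)no2)cc1`: > 100000 nM
compound 2, `COc1cccc(-c2cc(-c3cc4ccccc4n3C)on2)c1`: > 100000 nM
compound 3, `COc1cccc(-c2cc(-c3cc4ccccc4[nH]3)no2)c1`: > 100000 nM

Compound 1 stands at a limit of this assay, not at a measured number. The same holds for compound 2, and for compound 3. All three values shown sit at the limit of > 100000 nM in this assay, at which 3 of the 3 values shown sit, so none of the three can be ranked against another; nothing here says which is the stronger or the weaker inhibitor, only that none reached a measurable half-maximal inhibitory concentration within the tested range.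

The compound yet to be measured is compound 4, `COc1ccc(-c2cc(-c3cc4ccccc4[nH]3)no2)cc1`. It differs from compound 1 in one place: hydrogen in place of methyl on an aromatic nitrogen. Among the compounds with values here, no step between two measured compounds covers this change, so its size has to be guessed. Within the data shown here, the only hint is that compound 3, which also carries hydrogen on that aromatic nitrogen, likewise sits at the limit, while compound 2 with methyl there sits at the limit as well. The expected step is therefore a step that the limit leaves unreadable from compound 1 to compound 4, none beyond the scatter. Compound 4 is estimated at 150000 nM, within a range from 50000 nM to 400000 nM, and most probably this assay will again report only a limit.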

Compound 4, half-maximal inhibitory concentration: > 100000 nM
Compound 4: a limit, no number; the forecaster's own chance of this, stated with the estimate: 85%; the middle value is on the limit's open side.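

In this assay compound 4 gives > 100000 nM, which is a limit and not a number. No step can be read between compound 1 and compound 4, as both stand at a limit: the limit of > 100000 nM in this assay, at which 4 of the 4 values shown sit.

The compounds shown leave open whether hydrogen in place of methyl on the aromatic nitrogen changes the half-maximal inhibitory concentration at all.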